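Adding a Methyl to a Small Urea Nitrile

The compounds below may be only part of what the source reports. "The series", "measured", "known", "first", "only" and "open" are said of these compounds alone.

Of the compounds shown here, three sharing one core have been measured in a functional assay on RPMI-8226 cells (Homo sapiens) for inhibition; on this read-out lower numbers stand for stronger inhibition and higher numbers for weaker inhibition. Compound 1 `CCOC(=O)c1ccc(NC(=O)N2CC2C#N)cc1` gives 3000 nM. Compound 3 `N#CC1CN1C(=O)Nc1ccccc1` gives 5300 nM, and the step of a 1.8-fold higher number from compound 1 to compound 3 (0.25 log units; within the scatter) shows that removing the ester on the ring changes little. Compound 2 `CNC(=O)N1CC1C#N` gives 26000 nM, the highest of the three numbers, with both gaps to the other two lying beyond the scatter; it is therefore the weakest of the set.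

Compound 4 `CCNC(=O)N1CC1C#N` differs from compound 2 in one place: methyl in place of hydrogen on a saturated chain carbon bound to an amide-type nitrogen. For the measured compounds named here, no measured step touches this position; the only step at hand, a 1.8-fold higher number from compound 1 to compound 3 (0.25 log units; within the scatter), concerns a substituent on the aromatic ring, far from the amide-type nitrogen. The values of compound 2 and compound 3 show that a larger group on that nitrogen goes with a lower number, but methyl to ethyl is a much smaller change than methyl to phenyl. A modest step is therefore expected, a 1.4-fold lower number from compound 2 to compound 4 (0.16 log units; within the scatter), and compound 4 is estimated at 18000 nM, in the range 7000 nM to 45000 nM.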

Compound 4, half-maximal inhibitory concentration: 22000 nM
Estimate against measurement, compound 4: 1.2-fold (0.09 log units) below; the range from low to high includes it.
By their numbers in this assay, from the lowest: compounds 1 and 3 (each within the scatter of the next); then compounds 4 and 2 (each within the scatter of the next).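

In this assay, for the compounds shown here, the first measured step at this position, methyl in place of hydrogen on a saturated chain carbon bound to an amide-type nitrogen, gives a 1.2-fold lower number from compound 2 to compound 4 (0.07 log units; within the scatter). Methyl to ethyl at this position therefore produces no change that can be told apart from the ordinary spread of repeated measurements, so compound 2 and compound 4 cannot be ranked against each other. Going by these compounds alone, the only earlier step concerned a group on the aromatic ring, and no measurement at hand explains the outcome at this position.

Going by these compounds, it remains open whether a longer chain, such as butyl, or a chain carrying an amine or a carboxylic acid, would shift the number beyond that spread. A benzyl group would test the range between ethyl and the phenyl group of compound 3.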